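The source may hold more compounds than are shown below. What is called first, only, known or untested is meant among the compounds shown, and "the series" means these compounds.

Notes on the series assayed in an assay on MDA-MB-231 cells for binding affinity to C-X-C chemokine receptor type 4 (Homo sapiens), read by immunofluorescence and microscopy, with stated times of 10 min and 30 min; on this read-out lower numbers stand for an effect already at smaller amounts and higher numbers for an effect only at larger amounts of compound. Compound 1 `COc1ccc(C(=O)NCc2ccc(CNS(=O)(=O)c3ccccc3)cc2)cc1` gives 1000 nM. Compound 2 `COc1ccc(C(=O)NCc2ccc(CNS(=O)(=O)c3ccc(C)cc3)cc2)cc1` gives 100 nM, the second highest of the three numbers, with compound 1 nearest and compound 3 furthest. Compound 3 `Cc1ccccc1C(=O)NCc1ccc(CNS(=O)(=O)c2ccccc2)cc1` gives 1 nM. The measured steps are a 10-fold lower number from compound 1 to compound 2 (1.00 log units; beyond the scatter) and a 1000-fold lower number from compound 1 to compound 3 (3.00 log units; beyond the scatter). Compound 4 `Cc1ccc(C(=O)NCc2ccc(CNS(=O)(=O)c3ccc(C)cc3)cc2)cc1` differs from compound 2 by methyl in place of methoxy on an aromatic carbon. Going by the values given here, only the step from compound 1 to compound 3 touches the carbonyl-bound ring, and there 2-methylphenyl rather than 4-methylphenyl enters, so it bears only loosely; the other step concerns the sulfonyl-bound ring. For compound 4 in this assay a step of a 2.0-fold lower number from compound 2 to compound 4 (0.30 log units; within the scatter) towards a lower number is expected. The estimate for compound 4 is 50 nM, ranging from 10 nM to 300 nM.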

Compound 4, effective concentration (reported as EC, without a stated level of effect): 1000 nM
For compound 4 the middle estimate is 20-fold (1.30 log units) below the measured one; measured number above the stated range.
By their numbers in this assay, from the lowest: compound 3; then compound 2; then compounds 1 and 4 (each within the scatter of the next).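

Methoxy on the carbonyl-bound ring is not interchangeable with methyl: at this place, para to a large group, the exchange alone gives a 10-fold higher number from compound 2 to compound 4 (1.00 log units; beyond the scatter). The earlier step on this ring changed the group and its place together, whereas this one isolates the group at a single place. Nothing available explains the difference.

Still open, from the compounds shown here alone, is whether an amine or a hydroxyl group at this place would match methoxy. Also open, going by these compounds, is whether the step would hold with the sulfonyl-bound ring of compound 1.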